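Shortening the butyl group of compound 3 to propyl

The compounds below may be only part of what the source reports. "The series", "measured", "known", "first", "only" and "open" are said of these compounds alone.

Among the measured compounds shown here, in a functional assay on SH-SY5Y cells (Homo sapiens) for cytotoxicity, read by MTT assay, with a stated time of 72 h (on this read-out lower numbers stand for stronger inhibition and higher numbers for weaker inhibition), compound 3 `CCCCN1CCN(CCCCn2c3c(c4ccccc42)C(=O)c2c[n+]([O-])c4ccccc4c2C3=O)CC1` gives 6100 nM, the highest of the actual numbers measured so far. Compound 1 `O=C1c2c[n+]([O-])c3ccccc3c2C(=O)c2c1c1ccccc1n2CCCCn1ccnc1` gives 130 nM, far lower. Compound 2 `O=C1c2c[n+]([O-])c3ccccc3c2C(=O)c2c1c1ccccc1n2Cc1cn(C[C@H](O)CO)nn1` gives > 1000 nM, which is a limit of the assay and not a number.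

Compound 4 `CCCN1CCN(CCCCn2c3c(c4ccccc42)C(=O)c2c[n+]([O-])c4ccccc4c2C3=O)CC1` has not yet been measured. It differs from compound 3 by hydrogen in place of methyl on a saturated chain carbon, three bonds along the chain from an amine nitrogen in a ring, a change that turns butyl into propyl, with hydrogen in place of methyl on a saturated chain carbon, three bonds along the chain from an amine nitrogen in a ring.

The closest measured step is a 47-fold higher number from compound 1 to compound 3 (1.67 log units; beyond the scatter), which is large, but it exchanges 1H-imidazol-1-yl for the whole 4-butylpiperazin-1-yl group. The other, an at least 7.6-fold higher number from compound 1 to compound 2 (0.88 log units; beyond the scatter), also exchanges a whole side group. For the measured compounds named here, no measured step shortens a chain alone, so neither size carries over directly to this much smaller edit.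

No shift beyond the usual scatter is expected, with an estimated 1.2-fold lower number from compound 3 to compound 4 (0.09 log units; within the scatter). For compound 4 the expected value is 5000 nM, with an estimated range of 2000 nM to 12000 nM.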

Compound 4, half-maximal inhibitory concentration: 3970 nM
The estimate for compound 4 lay 1.3-fold (0.10 log units) above the measured number; the range from low to high includes it.
By their numbers in this assay, from the lowest: compound 1; then compounds 4 and 3 (each within the scatter of the next).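

In this assay, among the compounds shown here, the first step that edits only the end of this chain gives a 1.5-fold lower number from compound 3 to compound 4 (0.19 log units; within the scatter), so exchanging butyl for propyl does not separate the two compounds. The distance from the imidazole compound remains, with a 31-fold higher number from compound 1 to compound 4 (1.48 log units; beyond the scatter), which shows that the large gap seen with the 4-butylpiperazin-1-yl group also holds for the 4-propylpiperazin-1-yl group. Compound 2 carries a limit and not a number, so its step to compound 4 cannot be read: the limit of > 1000 nM in this assay, at which 1 of the 4 values shown sits.

From the compounds shown here alone, it remains open whether a much shorter group such as methyl, or a longer chain such as hexyl, on this piperazine would move the number beyond the scatter. Going by these compounds, it is also open whether a different amine, such as morpholin-4-yl, in place of the piperazine would bring the number closer to that of compound 1.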